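The source may hold more compounds than are shown below. What is called first, only, known or untested is meant among the compounds shown, and "the series" means these compounds.

Working notes on the series. Three compounds share one core and differ in a single group on an aromatic carbon: compound 1 `Cc1ccc2nc(Nc3ccnc(Nc4ccc(S(C)(=O)=O)cc4)n3)sc2c1` carries a methyl, compound 2 `CS(=O)(=O)c1ccc(Nc2nccc(Nc3nc4ccc(Cl)cc4s3)n2)cc1` a chloro, and compound 3 `COc1ccc2nc(Nc3ccnc(Nc4ccc(S(C)(=O)=O)cc4)n3)sc2c1` a methoxy. In a functional assay on MCF7 cells (Homo sapiens) for antiproliferative activity, read by MTT assay, with a stated time of 48 h (on this read-out lower numbers stand for stronger inhibition and higher numbers for weaker inhibition), compound 1 gives only a limit, > 50000 nM. In this assay compound 2 likewise gives only a limit, > 50000 nM. In this assay compound 3 also gives only a limit, > 50000 nM. Compound 2 therefore stands at the common limit, (the limit of > 50000 nM in this assay, at which 3 of the 3 values shown sit), with no number of its own. The three steps among the measured compounds, a step that the two limits leave unreadable from compound 1 to compound 2, a step that the two limits leave unreadable from compound 1 to compound 3 and a step that the two limits leave unreadable from compound 2 to compound 3, are each left unreadable by the two limits.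

Compound 4 `Cc1cnc(Nc2ccc(S(C)(=O)=O)cc2)nc1Nc1nc2ccc(Cl)cc2s1` differs from compound 2 by one change: methyl in place of hydrogen on an aromatic carbon. Going by the values given here, no measured step bears directly on this change, and none of the three measured steps has a readable size or direction, so the expectation for compound 4 rests on the fact that every measured value in this assay sits at the limit. The expected step is a step that the limit leaves unreadable from compound 2 to compound 4, with no step beyond the scatter. Compound 4 is estimated at 60000 nM in this assay, within a range from 15000 nM to 200000 nM, and a renewed limit is the likelier outcome.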

Compound 4, half-maximal inhibitory concentration: 4320 nM
Estimate against measurement, compound 4: 14-fold (1.14 log units) above; the measured number lies below the stated range.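

In this assay, the ring with 2 nitrogen proves to be a place where the read-out can move: methyl in place of hydrogen on an aromatic carbon of that ring, ortho to a large group and para to a large group, gives an at least 11-fold lower number from compound 2 to compound 4 (1.06 log units; beyond the scatter). Going by these compounds alone, the earlier steps, all on a different aromatic carbon, cannot be read, so they showed no change of any size, whereas this single added carbon atom, with no ring, no hydrogen-bond donor or acceptor and no net charge, takes the series off its common limit for the first time. Compound 4 is now the only compound shown with a number of its own, and the other three remain at a limit: the limit of > 50000 nM in this assay, at which 3 of the 4 values shown sit.

The compounds shown leave open whether this step is particular to methyl or would also appear with an ethyl, an amine or a fluorine on the same carbon. Within the data shown here, they also leave open whether the same methyl would give a readable number with a methyl or a methoxy in place of the chloro, since this change is seen only with the chloro present.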